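Trifluoromethyl for chloro on the urea aryl of compound 1

The source may hold more compounds than are shown below. What is called first, only, known or untested is meant among the compounds shown, and "the series" means these compounds.

Compound 1 `O=C(Nc1cccc(-n2cc(-c3ccncc3)c(-c3ccc(Cl)c(O)c3)n2)c1)Nc1ccc(Cl)c(Cl)c1` is one of three compounds assessed in a functional assay on OVCAR-3 cells (Homo sapiens) for inhibition, read by sulforhodamine B assay, with a stated time of 48 h (on this read-out higher numbers stand for weaker inhibition of growth and lower numbers for stronger inhibition of growth), where compound 1 gives 3150 nM. This is the second highest of the three numbers. Compound 2 `COc1cc(-c2nn(-c3cccc(NC(=O)Nc4cccc(C(F)(F)F)c4)c3)cc2-c2ccncc2)ccc1Cl` gives 1870 nM, and compound 1 lies within the scatter of that value. Among the compounds with values here, compound 3 `COc1cc(-c2nn(-c3cccc(NC(=O)c4ccccc4)c3)cc2-c2ccncc2)ccc1Cl` gives 10900 nM; the only single-point step among the measured compounds is a 5.8-fold higher number from compound 2 to compound 3 (0.77 log units; beyond the scatter), which concerns the carbonyl substituent and does not touch the change considered here.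

Compound 4 `O=C(Nc1cccc(-n2cc(-c3ccncc3)c(-c3ccc(Cl)c(O)c3)n2)c1)Nc1ccc(Cl)c(C(F)(F)F)c1` differs from compound 1 at the urea aryl ring: trifluoromethyl in place of chloro on an aromatic carbon. Within the data shown here, no measured step bears directly on this change. Compound 2 carries a trifluoromethyl on its urea aryl and its value sits within the scatter of compound 1, so no step beyond the scatter is expected in this assay. Compound 4 is therefore estimated at 2500 nM, with a range of 900 nM to 6500 nM, corresponding to an expected step of a 1.3-fold lower number from compound 1 to compound 4 (0.10 log units; within the scatter).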

Compound 4, concentration for total growth inhibition: 2090 nM
The estimate for compound 4 lay 1.2-fold (0.08 log units) above the measured number, and the stated range covers the measured number.
By their numbers in this assay, from the lowest: compounds 2, 4 and 1 (each within the scatter of the next); then compound 3.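

In this assay, within the data shown here, trifluoromethyl in place of chloro on the urea aryl ring gives a 1.5-fold lower number from compound 1 to compound 4 (0.18 log units; within the scatter), a direct reading of this change that the earlier compounds could not supply. At this position, ortho to a chloro group and meta to a large group, the 3,4-dichlorophenyl and 4-chloro-3-(trifluoromethyl)phenyl ureas therefore cannot be told apart on this read-out, even though the entering group has 4 heavy atoms and the leaving group has 1. Nothing available explains why the two groups read alike.

From the compounds shown here alone, whether the same holds for a nitrile, an amine or a carboxylic acid at this position remains open. Compounds 1 and 2 differ in more than one place, so the separate contributions of the hydroxy and methoxy groups also remain unresolved.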